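Tolerated concentrations in the series so far

The source may report more compounds than this note shows. Statements on the series, on what has been measured and on what is new or still open speak of the compounds shown alone.

Measured compounds:
compound 1 `O=C1N(Cc2ccccc2Br)c2cccn2S(=O)(=O)N1Cc1cccc(F)c1`: > 269000 nM
compound 2 `C=CCN1C(=O)N(Cc2ccccc2)S(=O)(=O)n2cccc21`: > 802000 nM
compound 3 `O=C1N(Cc2ccccc2Cl)c2cccn2S(=O)(=O)N1Cc1cccc(Br)c1`: > 260000 nM

In an ADME assay on MT4 cells (Homo sapiens) for cytotoxicity, read by MTT assay, with a stated time of 5 days (a lower number here means that less compound is tolerated, a higher number that more compound is tolerated), every value recorded so far is a limit of the assay and not a number. Compound 1 sits at the limit of > 269000 nM in this assay, at which 1 of the 3 values shown sits, and is therefore known only as a limit. Compound 2 is likewise reported only as a limit, at the limit of > 802000 nM in this assay, at which 1 of the 3 values shown sits. Compound 3 is also known only as a limit, at the limit of > 260000 nM in this assay, at which 1 of the 3 values shown sits. No pair of these compounds differs in a single place, so no measured step can be read from them, and nothing can be said about one being better tolerated than another.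

Compound 4 `O=C1N(Cc2ccccc2Br)c2cccn2S(=O)(=O)N1Cc1ccccc1` is not yet measured in this assay. Against compound 1 the change is hydrogen in place of fluoro on an aromatic carbon. For the measured compounds named here, with three limits and no measured step to rest on, no shift beyond the usual scatter is expected in this assay from this change; the most likely outcome for compound 4 is again a limit rather than a number. The step from compound 1 to compound 4 is expected to be a step that the limit leaves unreadable from compound 1 to compound 4. For compound 4 the expected value in this assay is 300000 nM, between 150000 nM and 900000 nM.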

Compound 4, half-maximal cytotoxic concentration: 226000 nM
Compound 4: the middle estimate sits 1.3-fold (0.12 log units) above what was measured, and the stated range covers the measured number.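

In this assay, for the compounds shown here, compound 4 gives 226000 nM, the first number that is not a limit. Hydrogen in place of fluoro on an aromatic carbon gives an at least 1.1-fold lower number from compound 1 to compound 4 (0.07 log units; that floor lies within the scatter), so the change from 3-fluorophenyl to phenyl shows no shift beyond the scatter so far, and its true size stays open because compound 1 is known only as a limit: the limit of > 269000 nM in this assay, at which 1 of the 4 values shown sits. Going by these compounds alone, the other change, 2-bromophenyl in place of vinyl on a saturated chain carbon bound to an amide-type nitrogen in a ring, gives an at least 3.5-fold lower number from compound 2 to compound 4 (0.55 log units; beyond the scatter), the first step that is beyond the scatter, with less compound tolerated where the 2-bromophenyl group is present.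

The compounds shown leave open whether an amine or a carboxylic acid in place of fluoro on this aromatic carbon would move the number beyond the scatter from the value of compound 4. They also leave open how large the step from vinyl to 2-bromophenyl really is, and whether a longer chain at that carbon would lower the tolerated concentration as well.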